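The compounds below may be only part of what the source reports. "The series", "measured", "known", "first", "only" and "open" are said of these compounds alone.

Compound 1 `Cc1ccccc1Cn1cc(COc2ccc3c(=O)ccoc3c2)nn1` and compound 2 `O=c1ccoc2cc(OCc3cn(Cc4ccc(F)cc4)nn3)ccc12` share one core and differ only in the group on a saturated chain carbon bound to an aromatic nitrogen. In an ADME assay on L02 cells (Homo sapiens) for cytotoxicity, read by MTT assay, with a stated time of 48 h (a higher number here means a weaker inhibitor, a lower number a stronger inhibitor), compound 1 gives only a limit, > 300000 nM. In this assay compound 2 likewise gives only a limit, > 300000 nM. For the measured compounds named here, the single measured step, a step that the two limits leave unreadable from compound 1 to compound 2, therefore cannot be sized. Compound 3 `O=c1ccoc2cc(OCc3cn(Cc4ccc(Br)cc4)nn3)ccc12` carries bromo in place of fluoro on an aromatic carbon. The measured step bears on this change only in showing that a swap at the same place left both compounds at the limit, as the limit of > 300000 nM in this assay, at which 2 of the 2 values shown sit, records. Going by the values given here, no step of readable size is known, so no step beyond the scatter is expected in this assay. Compound 3 is therefore estimated at about 300000 nM, within 100000 nM to 1000000 nM, most likely reported again as a limit. The expected step from compound 2 to compound 3 is a number no higher from compound 2 to compound 3 (the limit leaves the size open).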

Compound 3, half-maximal inhibitory concentration: > 300000 nM
Compound 3 was reported as a limit; the forecaster's own chance of this, stated with the estimate: 85%; the middle value lies on the limit itself.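

No new step can be read among compound 1, compound 2 and compound 3 in this assay, since each value is only a limit: the limit of > 300000 nM in this assay, at which 3 of the 3 values shown sit.

The compounds shown leave open how these three compare with one another and whether any change at this place would give a readable value.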